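This account rests on a few compounds, and the source may have more. Where it says the series, first, only, none or still open, it means among the compounds named here.

In a functional assay on SK-MEL-28 cells (Homo sapiens) for cytotoxicity, read by MTT assay, with a stated time of 3 days (a higher number here means a weaker inhibitor, a lower number a stronger inhibitor), compound 1 `N#Cc1c(O)nc(SCc2nc3ccccc3[nH]2)nc1-c1ccccc1` gives 7.7 nM and compound 2 `N#Cc1c(-c2ccccc2)nc(SCc2nc3ccccc3[nH]2)nc1N1CCNCC1` gives 2.6 nM, the lower of the two numbers. Within the data shown here, the only measured step is a 3.0-fold lower number from compound 1 to compound 2 (0.47 log units; beyond the scatter), with piperazin-1-yl in place of hydroxy on an aromatic carbon. Compound 3 `CN1CCN(c2nc(SCc3nc4ccccc4[nH]3)nc(-c3ccccc3)c2C#N)CC1` differs from compound 2 by methyl in place of hydrogen on an amine nitrogen in a ring. Among the measured compounds shown here, no measured step tests this change, so that modest step is only a loose guide, and no shift beyond the scatter is expected in this assay. The expected step is a 1.2-fold higher number from compound 2 to compound 3 (0.06 log units; within the scatter). For compound 3 the estimated value is 3 nM, within an expected range of 1 nM to 9 nM.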

Compound 3, half-maximal inhibitory concentration: 20 nM
Estimate against measurement, compound 3: 6.7-fold (0.82 log units) below, outside the stated range (above it).
By their numbers in this assay, from the lowest: compound 2; then compound 1; then compound 3.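

In this assay, the step from piperazin-1-yl to 4-methylpiperazin-1-yl is a 7.7-fold higher number from compound 2 to compound 3 (0.89 log units; beyond the scatter), showing that this position on the ring amine nitrogen is sensitive to a single methyl. Against the hydroxy compound, the direction reverses: the 4-methylpiperazin-1-yl replacement gives a 2.6-fold higher number from compound 1 to compound 3 (0.41 log units; beyond the scatter), whereas the unsubstituted piperazin-1-yl replacement had given a lower number. No available evidence accounts for this shift. Still open, as far as these compounds go, is whether a longer chain such as ethyl, or an acetyl group, on the same nitrogen would follow methyl.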